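Phenoxymethyl for 4-methylphenyl on a carbonyl carbon

This account rests on a few compounds, and the source may have more. Where it says the series, first, only, none or still open, it means among the compounds named here.

Compound 1 `O=C(COc1ccccc1)Nc1nnc(-c2cccc(O)c2O)s1` gives 10500 nM
Compound 2 `Cc1ccc(C(=O)Nc2nnc(-c3ccc(O)c(O)c3)s2)cc1` gives 11800 nM

Among the compounds with values here, in a functional assay on A549 cells (Homo sapiens) for cytotoxicity, read by MTT assay, with a stated time of 72 h (on this read-out lower numbers stand for stronger inhibition and higher numbers for weaker inhibition), compound 2 at 11800 nM stands level, within the usual scatter, with compound 1 at 10500 nM on the only two numbers available. Compound 3 `O=C(COc1ccccc1)Nc1nnc(-c2ccc(O)c(O)c2)s1` carries phenoxymethyl in place of 4-methylphenyl on a carbonyl carbon. Within the data shown here, no measured step shows what such an exchange does in this assay and the expectation therefore rests on little. Compound 1, which also bears phenoxymethyl, gives 10500 nM and so offers no reason to expect a shift in either direction. The expected outcome is a 1.1-fold lower number from compound 2 to compound 3 (0.03 log units; within the scatter) and thus no change beyond the scatter. For compound 3 the estimated value is 11000 nM with an expected range from 5000 nM to 25000 nM in this assay.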

Compound 3, half-maximal inhibitory concentration: 21200 nM
Estimate against measurement, compound 3: 1.9-fold (0.28 log units) below; low and high end bracket the measured number.
By their numbers in this assay, from the lowest: compounds 1, 2 and 3 (each within the scatter of the next, the first and the last beyond it).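

In this assay, phenoxymethyl in place of 4-methylphenyl on a carbonyl carbon gives a 1.8-fold higher number from compound 2 to compound 3 (0.25 log units; within the scatter) and so shows no shift that can be told from the scatter at this position. With phenoxymethyl held constant, 3,4-dihydroxyphenyl in place of 2,3-dihydroxyphenyl on an aromatic carbon gives a 2.0-fold higher number from compound 1 to compound 3 (0.31 log units; beyond the scatter) as a modest step, the only one here that passes the scatter, and it comes from the dihydroxyphenyl group and not from the carbonyl substituent. Nothing measured here accounts for either step.

From the compounds shown here alone, it remains open whether the modest dihydroxyphenyl step would recur with 4-methylphenyl on the carbonyl carbon. Also open, going by these compounds, is whether an amine or a longer chain at that carbonyl carbon, or methoxy groups in place of the hydroxy groups, would move the number beyond the scatter.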